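The source may hold more compounds than are shown below. What is called first, only, known or untested is meant among the compounds shown, and "the series" means these compounds.

For the measured compounds named here, compound 3, drawn as `CN(C)c1ccc2c(c1)O[C@@H]([C@@H]1CCCN1C)CO2`, is the weakest of the three measured members in an assay on membranes from Cerebral cortex for displacement of a labelled ligand from Neuronal acetylcholine receptor; alpha4/beta2 (Rattus norvegicus), with a stated time of 5 min; a lower number here means a stronger inhibitor, a higher number a weaker inhibitor: compound 3 gives 49000 nM. The nearest neighbour is compound 2, `CN1CCC[C@H]1[C@@H]1COc2ccc([N+](=O)[O-])cc2O1`, which in this assay gives 14000 nM; the furthest is compound 1, `CN1CCC[C@H]1[C@@H]1COc2ccc(N)cc2O1`, which in this assay gives 22 nM. Going by the values given here, the one single-point step that has been measured, a 640-fold higher number from compound 1 to compound 2 (2.80 log units; beyond the scatter), arises from a nitro in place of an amino group on an aromatic carbon and says nothing about configuration.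

Compound 4, drawn as `CN(C)c1ccc2c(c1)O[C@H]([C@@H]1CCCN1C)CO2`, is related to compound 3 in a different way: the two compounds have the same atoms and bonds and differ only in configuration as drawn: 1 of 2 stereo elements differ; a stereocentre at a saturated ring carbon is drawn S in compound 3 and R in compound 4. Among the compounds with values here, no measured pair in this set changes a stereocentre, so there is no step on which to rest an expectation of direction or size, and the inversion could in principle shift the number in either direction in this assay. In the absence of any bearing step, compound 4 is expected to stay close to compound 3, with a step of a 1.6-fold lower number from compound 3 to compound 4 (0.21 log units; within the scatter) that is not expected to exceed the scatter, while the range is kept wide. Compound 4 is therefore estimated at 30000 nM in this assay, within the range 5000 nM to 150000 nM.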

Compound 4, inhibition constant: 147000 nM
For compound 4 the middle estimate is 4.9-fold (0.69 log units) below the measured one, and the stated range covers the measured number.
By their numbers in this assay, from the lowest: compound 1; then compound 2; then compound 3; then compound 4.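

In this assay the inversion of a stereocentre at a saturated ring carbon, drawn S in compound 3 and R in compound 4, gives a 3.0-fold higher number from compound 3 to compound 4 (0.48 log units; beyond the scatter), the first measured sign in this series that configuration alone can move the number, and that shift can be set on this centre alone because of the following: the fact that compounds 3 and 4 differ only in the configuration as drawn.

At the aromatic carbon, dimethylamino in place of nitro gives an 11-fold higher number from compound 2 to compound 4 (1.02 log units; beyond the scatter), so the order among these groups now extends past the nitro compound.

Dimethylamino in place of amino gives a 6700-fold higher number from compound 1 to compound 4 (3.82 log units; beyond the scatter), a step larger than the one seen for nitro in place of amino, which leaves amino as the only one of the three groups at this carbon with a number far below the others.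

The compounds shown leave open whether the same inversion would shift the number in the same direction, or by a similar size, with amino or nitro at the aromatic carbon, and what inverting the other stereocentre would do. They also leave open where methylamino, a single methyl on that nitrogen, or a hydroxyl or methoxy group at that carbon would fall.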